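The source may report more compounds than this note shows. Statements on the series, on what has been measured and on what is new or still open speak of the compounds shown alone.

Measured compounds:
compound 1, `Cc1c(OCCCCOCOc2ccc(C(=O)O)cc2)ccc(C(=O)CC2CCCC2)c1O`, giving 46.9% in an assay on HEK293 cells for positive allosteric modulation of metabotropic glutamate receptor 3 (Rattus norvegicus), read by thallium flux, with a stated time of 2.5 min; on this read-out higher numbers stand for larger maximal responses and lower numbers for smaller maximal responses
compound 2, `CCCC(=O)c1ccc(OCCCCOc2cccc(C(=O)O)c2C)c(C)c1O`, giving 53% in this assay

Among the measured compounds shown here, only two compounds carry a number in this assay so far. For the measured compounds named here, compound 2 holds the upper of the two, but its nearest neighbour, compound 1, sits within the scatter of it, so the pair does not separate and no step between measured compounds can be drawn. Both numbers lie near the middle of the scale, and nothing in the set yet shows how a change at the carbonyl carbon moves the maximal response.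

Compound 3, `Cc1c(OCCCCOc2ccc(C(=O)C(C)C)c(O)c2C)cccc1C(=O)O`, is built from the same atoms as compound 2, joined differently. The difference is isopropyl in place of propyl on a carbonyl carbon; cut one bond further out it reads propylcarbonyl to isopropylcarbonyl, and the place is a carbonyl carbon whose other neighbour is an aromatic carbon.

Going by the values given here, with no measured step to lean on, the expected step from compound 2 to compound 3 in this assay is a number 3 percentage points lower from compound 2 to compound 3 (within the scatter), that is, none beyond the scatter in either direction. For compound 3 in this assay the estimate is 50%, with a range from 32% to 68%.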

Compound 3, largest response reached (reported as percent of maximum), in percent of the reference or control that the assay uses: 27.1%
Estimate against measurement, compound 3: 22.9 percentage points above; measured number outside the range, below it.
By their numbers in this assay, from the lowest: compound 3; then compounds 1 and 2 (each within the scatter of the next).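

The carbonyl carbon whose other neighbour is an aromatic carbon now proves sensitive in this assay to how its three-carbon group is joined, with isopropyl in place of propyl giving a clear loss of maximal response (a number 25.9 percentage points lower from compound 2 to compound 3 (beyond the scatter)). Among the compounds shown here, this is the first step that can be read beyond the scatter, and it arises with no change in atoms, ring count, hydrogen-bond donors or acceptors in the exchanged group, so these counts alone do not predict the response at this position. No measurement bearing on the origin of this drop is available.

Going by these compounds, the finding rests on a single pair, so it remains open whether the drop extends to other groups at this carbonyl carbon, such as cyclopropyl, tert-butyl or a longer chain such as butyl. On these data alone, it also remains open whether the same exchange costs as much on a different core, or whether an amine or a second carboxylic acid at this place would restore the response.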